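Four stereoisomers of a hydroxyproline-serine dipeptide in colon stability

The compounds below may be only part of what the source reports. "The series", "measured", "known", "first", "only" and "open" are said of these compounds alone.

Three stereoisomers of the same dipeptide have been examined in an ADME assay on Colon (Mus musculus, strain C57BL/6) for metabolic stability, read by HPLC, with a stated time of 12 h; a higher number here means that the compound lasts longer, a lower number that the compound disappears faster. Compound 1 `O=C(N[C@H](CO)C(=O)O)[C@@H]1C[C@H](O)CN1` reaches only the limit of the measurement, giving > 12 h in this assay. Compound 2 `O=C(O)[C@H](CO)NC(=O)[C@H]1C[C@@H](O)CN1` likewise gives > 12 h in this assay, again a limit rather than a number. Compound 3 `O=C(O)[C@H](CO)NC(=O)[C@@H]1C[C@H](O)CN1` also stops at the limit, giving > 12 h in this assay. Because all three sit at the limit (the limit of > 12 h in this assay, at which 3 of the 3 values shown sit), none of the three steps among them can be read: a step that the two limits leave unreadable from compound 1 to compound 2, a step that the two limits leave unreadable from compound 1 to compound 3 and a step that the two limits leave unreadable from compound 2 to compound 3 remain of unknown size and direction, although each pair differs only in configuration (the fact that compounds 1 and 2 differ only in the configuration as drawn, (the fact that compounds 1 and 3 differ only in the configuration as drawn), (the fact that compounds 2 and 3 differ only in the configuration as drawn)).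

Compound 4 `O=C(O)[C@@H](CO)NC(=O)[C@H]1C[C@H](O)CN1` is the fourth member of this set. Its difference from compound 3 is the two compounds have the same atoms and bonds and differ only in configuration as drawn: 2 of 3 stereo elements differ; a stereocentre at a saturated chain carbon is drawn S in compound 3 and R in compound 4; a stereocentre at a saturated ring carbon is drawn S in compound 3 and R in compound 4. Going by the values given here, the three measured steps, all between stereoisomers that share a limit, give no readable size, so they offer no direction for the step to compound 4; they only show that every configuration tried so far has outlasted the measurement. On that basis the step that the limit leaves unreadable from compound 3 to compound 4 is expected to stay within the scatter. Compound 4 is therefore estimated at 20 h in this assay, within the range 12 h to 40 h, most likely reported once more as a limit.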

Compound 4, half-life in the Mus musculus assay: > 12 h
Compound 4: only a limit was reported (the forecaster's own chance of this, stated with the estimate: 85%); the middle value lies beyond the limit too.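

Going by these compounds alone, compound 4 also stops at the limit in the Mus musculus assay, so no step from it to compound 1, compound 2 or compound 3 can be read. In a physicochemical assay for metabolic stability, read by HPLC, with a stated time of 12 h, at pH 4.5 (on this read-out higher numbers stand for a longer-lived compound and lower numbers for a shorter-lived compound), compound 3 gives > 12 h, which is a limit. In the physicochemical assay compound 4 gives > 12 h, again a limit. The compounds shown leave open how long any of these stereoisomers actually lasts, and whether configuration changes that at all.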